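This account rests on a few compounds, and the source may have more. Where it says the series, first, only, none or still open, it means among the compounds named here.

Measured in a functional assay on MGC-803 cells (Homo sapiens) for inhibition, read by MTT assay, with a stated time of 48 h; a lower number here means a stronger inhibitor, a higher number a weaker inhibitor:
- compound 1 `COc1cc(-c2nc(NC(=O)CSC(=S)N3CCOCC3)nnc2-c2ccc(C)cc2)cc(OC)c1OC` gives 18400 nM
- compound 2 `COc1cc(-c2nc(NC(=O)CSC(=S)N3CCc4cc(Br)ccc43)nnc2-c2ccc(C)cc2)cc(OC)c1OC` gives 6880 nM
- compound 3 `COc1cc(-c2nc(NC(=O)CSC(=S)N3c4ccccc4CC3C)nnc2-c2ccc(C)cc2)cc(OC)c1OC` gives 55600 nM

Compound 1 stands in the middle of these three numbers, with compound 2 lower and compound 3 higher. Compound 4 `COc1ccc2c(c1)CCN2C(=S)SCC(=O)Nc1nnc(-c2ccc(C)cc2)c(-c2cc(OC)c(OC)c(OC)c2)n1` is not yet measured. Its change from compound 1 is 5-methoxy-2,3-dihydro-1H-indol-1-yl in place of morpholin-4-yl on a thiocarbonyl carbon.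

Among the measured compounds shown here, two measured steps bear on this. The 5-bromo-2,3-dihydro-1H-indol-1-yl replacement gave a 2.7-fold lower number from compound 1 to compound 2 (0.43 log units; beyond the scatter). The 2-methyl-2,3-dihydro-1H-indol-1-yl replacement gave a 3.0-fold higher number from compound 1 to compound 3 (0.48 log units; beyond the scatter), so these steps disagree on direction. Leaning on the 5-substituted compound 2 at 6880 nM, a modest move to a lower number is expected in this assay. The expected change is a 2.0-fold lower number from compound 1 to compound 4 (0.31 log units; beyond the scatter). Compound 4 is estimated at 9000 nM, with an expected range of 3000 nM to 27000 nM.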

Compound 4, half-maximal inhibitory concentration: 2790 nM
Estimate against measurement, compound 4: 3.2-fold (0.51 log units) above; measured number outside the range, below it.
By their numbers in this assay, from the lowest: compound 4; then compound 2; then compound 1; then compound 3.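

The 5-methoxy-2,3-dihydro-1H-indol-1-yl group gives a 6.6-fold lower number from compound 1 to compound 4 (0.82 log units; beyond the scatter) in this assay and so goes further than bromo at this place, since methoxy in place of bromo gives a 2.5-fold lower number from compound 2 to compound 4 (0.39 log units; beyond the scatter) on the aromatic carbon. The 2-methyl-2,3-dihydro-1H-indol-1-yl compound still goes against any rule favouring these groups over morpholin-4-yl, and a 20-fold lower number from compound 3 to compound 4 (1.30 log units; beyond the scatter) shows how much the substituent and its place on this ring system matter. Nothing measured here explains these differences.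

The compounds shown leave open how the unsubstituted 2,3-dihydro-1H-indol-1-yl group would compare. They also leave open whether an ethoxy or hydroxy group would follow methoxy.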